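A few compounds are considered here, and "the series" means these few. Any claim that something is new, unique, unknown or untested is made for them only; others in the source may bear on it.

Compound 1 `COc1cc(C(=O)c2sc(-c3ccc(C)cc3)cc2N)cc(OC)c1OC`: in a functional assay on MOLT-4 cells (Homo sapiens) for antiproliferative activity (a lower number here means a stronger inhibitor, a higher number a weaker inhibitor), compound 1 gives 16 nM.
Compound 2 `COc1cc(C(=O)c2sc(-c3ccc(Cl)cc3)cc2N)cc(OC)c1OC`: in this assay compound 2 gives 77 nM.
Compound 3 `COc1ccc(-c2cc(N)c(C(=O)c3cc(OC)c(OC)c(OC)c3)s2)cc1OC`: in this assay compound 3 gives 20 nM.

Compound 1 has the lowest number of the three; compound 3 lies within the scatter of it, while compound 2 sits clearly further off, a 4.8-fold higher number from compound 1 to compound 2 (0.68 log units; beyond the scatter). Compound 4 `COc1ccc(-c2cc(N)c(C(=O)c3cc(OC)c(OC)c(OC)c3)s2)cc1` differs from compound 1 in one place: methoxy in place of methyl on an aromatic carbon. For the measured compounds named here, two measured steps bear on this change. The first, a 1.3-fold higher number from compound 1 to compound 3 (0.10 log units; within the scatter), also brings methoxy onto that ring and leaves the number essentially unchanged. The second, a 3.9-fold lower number from compound 2 to compound 3 (0.59 log units; beyond the scatter), runs the other way but concerns chloro. The chloro step itself shows that this ring does respond to some groups. On balance a step within the scatter is expected in this assay, a 1.3-fold higher number from compound 1 to compound 4 (0.10 log units; within the scatter). Compound 4 is therefore estimated at 20 nM, with a range from 8 nM to 50 nM.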

Compound 4, half-maximal inhibitory concentration: 18 nM
Estimate against measurement, compound 4: 1.1-fold (0.05 log units) above; the measured number falls inside the stated range.
By their numbers in this assay, from the lowest: compounds 1, 4 and 3 (each within the scatter of the next); then compound 2.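

In this assay, the change from 4-methylphenyl to 4-methoxyphenyl is on its own a step within the scatter (a 1.1-fold higher number from compound 1 to compound 4 (0.05 log units; within the scatter)), and removing one methoxy from the 3,4-dimethoxyphenyl group likewise stays within it (a 1.1-fold lower number from compound 3 to compound 4 (0.05 log units; within the scatter)). Methoxy and chloro at this place do separate, however (a 4.3-fold lower number from compound 2 to compound 4 (0.63 log units; beyond the scatter)), so only chloro among these groups stands apart. Nothing measured here gives a reason for these numbers.

Going by these compounds, whether fluoro or bromo would follow chloro remains open. So does whether an amine, a hydroxyl or a longer chain such as ethoxy would stay with methyl and methoxy.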